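Bis-benzylidene cyclohexanone series: catechol replacing methoxyphenyl

This account rests on a few compounds, and the source may have more. Where it says the series, first, only, none or still open, it means among the compounds named here.

Measured so far:
compound 1 `COc1cccc(/C=C2\CCC/C(=C\c3cccc(OC)c3OC)C2=O)c1`: 9900 nM
compound 2 `COc1ccc(/C=C2\CCC/C(=C\c3cccc(OC)c3OC)C2=O)cc1OC`: 6400 nM

In a functional assay on HT-1080 cells (Homo sapiens) for cytotoxicity, read by MTT assay, with a stated time of 72 h (on this read-out higher numbers stand for weaker inhibition and lower numbers for stronger inhibition), compound 1 gives the highest of the two numbers; compound 2 sits closest, the step of a 1.5-fold lower number from compound 1 to compound 2 (0.19 log units; within the scatter) being within the scatter. Compound 3 `COc1cccc(/C=C2\CCC/C(=C\c3ccc(O)c(O)c3)C2=O)c1OC` carries the change (3,4-dihydroxyphenyl in place of 3-methoxyphenyl on a double-bonded chain carbon bound to a double-bonded ring carbon). Within the data shown here, no measured step touches this change: the one step in hand adds a methoxy and stays within the scatter, so nothing in the data points to a direction. Compound 3 is therefore expected near compound 1, with a 1.3-fold lower number from compound 1 to compound 3 (0.12 log units; within the scatter) as the estimated step. The estimate for compound 3 is 7500 nM, range 2000 nM to 25000 nM.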

Compound 3, half-maximal inhibitory concentration: 4700 nM
Compound 3: the middle estimate sits 1.6-fold (0.20 log units) above what was measured, within the range that was stated.
By their numbers in this assay, from the lowest: compounds 3, 2 and 1 (each within the scatter of the next, the first and the last beyond it).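

In this assay, among these compounds, the place on a double-bonded chain carbon bound to a double-bonded ring carbon responds to a change of aryl group: 3,4-dihydroxyphenyl in place of 3-methoxyphenyl gives a 2.1-fold lower number from compound 1 to compound 3 (0.32 log units; beyond the scatter) and so provides the first step beyond the scatter, though a modest one. The entering group carries hydrogen-bond donors, which 3-methoxyphenyl lacks, but this single step does not separate their role from any other part of the swap. No measurement bears on why the number falls.

From the compounds shown here alone, it remains open whether a single hydroxy group would give a similar step. An aminophenyl or carboxyphenyl group at this place would test how far the step depends on the two hydroxy groups.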